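Swapping methyl for cyano on compound 1

A few compounds are considered here, and "the series" means these few. Any claim that something is new, unique, unknown or untested is made for them only; others in the source may bear on it.

- compound 1 `COC(=O)C1=C(C)N=C(C)/C(=C(/O)OC)C1c1cccc(OCc2no[n+]([O-])c2C)c1` gives 500 nM
- compound 2 `COC(=O)C1=C(C)N=C(C)/C(=C(/O)OC)C1c1ccccc1OCc1nonc1C` gives 41 nM
- compound 3 `COC(=O)C1=C(C)N=C(C)/C(=C(/O)OC)C1c1ccccc1OCc1no[n+]([O-])c1C(N)=O` gives 550 nM

In a functional assay (aorta) with Rattus norvegicus as the target, in the presence of a further agent that is not named here (a higher number here means that more compound is needed for the effect, a lower number that less compound is needed), compound 1 at 500 nM stands level with compound 3 at 550 nM. Compound 2 at 41 nM has clearly the smallest number among these three. Compound 4 `COC(=O)C1=C(C)N=C(C)/C(=C(/O)OC)C1c1cccc(OCc2no[n+]([O-])c2C#N)c1` is still unmeasured. Its change from compound 1 is cyano in place of methyl on an aromatic carbon and the rest of the structure stays the same.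

Among the compounds with values here, no measured pair makes this exact swap. The nearest evidence is a 13-fold higher number from compound 2 to compound 3 (1.13 log units; beyond the scatter) which is large, but there a whole ring group is replaced, not a single group on that ring. Compound 1 and compound 3 carry different groups on that ring and still lie within the scatter of each other, although they differ in more than that group. A direction therefore cannot be read from these data, and the range must stay wide. In this assay the expected result is a 1.3-fold lower number from compound 1 to compound 4 (0.10 log units; within the scatter) with no firm direction in this estimate. For compound 4 the estimated value is 400 nM with an expected range from 100 nM to 1500 nM around it.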

Compound 4, half-maximal effective concentration: 3.3 nM
For compound 4 the middle estimate is 120-fold (2.08 log units) above the measured one; measured number outside the range, below it.
By their numbers in this assay, from the lowest: compound 4; then compound 2; then compounds 1 and 3 (each within the scatter of the next).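

In this assay, putting cyano in place of methyl on this aromatic carbon gives a 150-fold lower number from compound 1 to compound 4 (2.18 log units; beyond the scatter), with the rest of the structure unchanged. This shows that a single small group at this position of the five-membered ring can shift the number far beyond the scatter. Within the data shown here, the only earlier step, a 13-fold higher number from compound 2 to compound 3 (1.13 log units; beyond the scatter), replaced a whole ring group, so it could not show what one group on that ring does alone, and nothing given here explains the size of the new step.

Going by these compounds, with only methyl and cyano compared at this position on the core of compound 1, it remains open whether the low number is particular to cyano. A trifluoromethyl group, a methyl ester or a longer chain on the same carbon would show how other groups compare.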